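Cyclopropyl to ethyl on compound 3

A few compounds are considered here, and "the series" means these few. Any claim that something is new, unique, unknown or untested is made for them only; others in the source may bear on it.

In a functional assay on HeLa cells (Homo sapiens) for antiproliferative activity, read by MTT assay, with a stated time of 72 h (a lower number here means a stronger inhibitor, a higher number a weaker inhibitor), compound 1 `CCn1cc(C(=O)O)c(=O)c2cc(F)c(N3CCN(C(=N)NS(=O)(=O)c4ccc(C(F)(F)F)cc4)CC3)cc21` gives 32 nM, compound 2 `CCn1cc(C(=O)O)c(=O)c2cc(F)c(N3CCN(C(=N)NS(=O)(=O)c4ccccc4Cl)CC3)cc21` gives 32 nM, and compound 3 `N=C(NS(=O)(=O)c1ccccc1C(F)(F)F)N1CCN(c2cc3c(cc2F)c(=O)c(C(=O)O)cn3C2CC2)CC1` gives 32 nM, so compound 3 stands level with the other two. The next compound, compound 4 `CCn1cc(C(=O)O)c(=O)c2cc(F)c(N3CCN(C(=N)NS(=O)(=O)c4ccccc4C(F)(F)F)CC3)cc21`, differs from compound 3 in one place: ethyl in place of cyclopropyl on an aromatic nitrogen. Going by the values given here, no measured step makes this exact swap. Among the compounds with values here, the only measured step, for 2-chlorophenyl in place of 4-(trifluoromethyl)phenyl on a sulfonyl sulfur, shows no change at the digits printed from compound 1 to compound 2 (within the scatter). It bears on the question only indirectly, as a sign that these numbers have not moved so far. More telling, compound 1 already carries ethyl on that nitrogen and gives 32 nM, the same number as compound 3 with cyclopropyl. No shift in either direction beyond the scatter is therefore expected in this assay, and the expected step is no change at the digits printed from compound 3 to compound 4 (within the scatter). The estimate for compound 4 is 32 nM, with an expected range from 14 nM to 75 nM.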

Compound 4, half-maximal inhibitory concentration: 32 nM
Beside the measured number, compound 4's estimate shows no gap at the digits printed, and the stated range covers the measured number.
By their numbers in this assay, from the lowest: compounds 1, 2, 3 and 4 (each within the scatter of the next).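

In this assay, the swap of cyclopropyl for ethyl on the aromatic nitrogen now has a direct reading, which is no change at the digits printed from compound 3 to compound 4 (within the scatter) and shows that this position tolerates losing the three-membered ring in this pair. Compound 4 also adds two comparisons on the sulfonyl side: trifluoromethyl in place of chloro on an aromatic carbon gives no change at the digits printed from compound 2 to compound 4 (within the scatter) and moving to 2-(trifluoromethyl)phenyl from 4-(trifluoromethyl)phenyl gives no change at the digits printed from compound 1 to compound 4 (within the scatter) in this series. No measurement available here explains why these changes leave the number in place.

Still open, from the compounds shown here alone, is whether a longer chain such as n-butyl, or a phenyl ring, on that nitrogen would keep the same activity. A methoxy group or a nitrile on the sulfonyl-bound ring also remains untested among the compounds shown.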